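Replacing the methylpyrazole on compound 2

The source may report more compounds than this note shows. Statements on the series, on what has been measured and on what is new or still open speak of the compounds shown alone.

Within the data shown here, compound 2 `Cn1cc(-c2nc3c(-c4ccc5c(c4)CCC[C@@H]5NC(=O)c4nc(C(C)(C)C)no4)ccnc3[nH]2)cn1` gives 190 ug/mL in a physicochemical assay for solubility, in simulated intestinal fluid (on this read-out lower numbers stand for lower solubility and higher numbers for higher solubility), the highest of the two numbers known so far; compound 1 `Cn1cc(-c2nc3c(-c4ccc(CNC(=O)c5nc(C(C)(C)C)no5)c(F)c4)ccnc3[nH]2)cn1` gives 2 ug/mL in this assay, a gap that lies well beyond the scatter. Compound 3 `Cc1nn(C2CCOCC2)cc1-c1nc2c(-c3ccc4c(c3)CCC[C@@H]4NC(=O)c3nc(C(C)(C)C)no3)ccnc2[nH]1` has not yet been measured. It differs from compound 2 by a group of 12 heavy atoms (9 carbon, 2 nitrogen, 1 oxygen; one five-membered aromatic ring with 2 hetero atoms, one six-membered non-aromatic ring with 1 hetero atom) in place of a group of 6 heavy atoms (4 carbon, 2 nitrogen; one five-membered aromatic ring with 2 hetero atoms), on an aromatic carbon. Among the measured compounds shown here, no step between two measured compounds is available to calibrate this change, so the expectation rests on compound 2 alone. The expected step is a 1.9-fold lower number from compound 2 to compound 3 (0.28 log units; within the scatter), a modest decrease that may fall within the scatter. Compound 3 is estimated at 100 ug/mL, with a range from 25 ug/mL to 300 ug/mL.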

Compound 3, solubility: 33 ug/mL
Beside the measured number, compound 3's estimate is 3.0-fold (0.48 log units) above it; measured number inside the range.
By their numbers in this assay, from the lowest: compound 1; then compound 3; then compound 2.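

In this assay, the first change shown at this position, on an aromatic carbon of the five-membered ring, is not silent: the larger group keeps a five-membered aromatic ring with 2 hetero atoms, adds a six-membered non-aromatic ring with 1 hetero atom, and brings a 5.8-fold lower number from compound 2 to compound 3 (0.76 log units; beyond the scatter). Nothing available here accounts for this step. This single step cannot show which part of the entering group carries the change. Going by these compounds, how an amine or a carboxylic acid on the non-aromatic ring would read in this assay remains open.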